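The source may report more compounds than this note shows. Statements on the series, on what has been measured and on what is new or still open speak of the compounds shown alone.

Working notes on a small series sharing one core, assessed in a functional assay on WI-38 VA13 cells (Homo sapiens) for cytotoxicity; a lower number here means that less compound is needed, a higher number that more compound is needed for the effect.

Among the compounds with values here, compound 1 `Cn1ncc([N+](=O)[O-])c1C(=O)Nc1ccc2nc(NC(=O)C3CCCCC3)sc2c1` gives 0.026 ug/mL and is the lowest number of the three measured so far. Compound 2 `O=C(Nc1ccc2nc(NC(=O)C3CCCCC3)sc2c1)c1cccc(F)c1` gives 0.64 ug/mL, and compound 3 `N#Cc1ccc(C(=O)Nc2ccc3nc(NC(=O)C4CCCCC4)sc3c2)cc1` gives 3.3 ug/mL. The two measured steps away from compound 1 are a 25-fold higher number from compound 1 to compound 2 (1.39 log units; beyond the scatter) and a 130-fold higher number from compound 1 to compound 3 (2.10 log units; beyond the scatter), both large and beyond the scatter; between the other two compounds the step is a 5.2-fold higher number from compound 2 to compound 3 (0.71 log units; beyond the scatter).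

Compound 4 `O=C(Nc1nc2ccc(NC(=O)C3CCCO3)cc2s1)C1CCCCC1` is not yet measured. It differs from compound 1 as follows: oxolan-2-yl in place of 1-methyl-4-nitro-1H-pyrazol-5-yl on a carbonyl carbon.

The steps from compound 1 to compound 2 and from compound 1 to compound 3 bear on this change, since in each of them the same 1-methyl-4-nitro-1H-pyrazol-5-yl on the carbonyl carbon is exchanged for another group, and in each case the number rose strongly. Within the data shown here, only two such exchanges are available, and neither brings in a non-aromatic ring, so the size is uncertain, but a large rise in the number is the expectation. For compound 4 the expected step is a 38-fold higher number from compound 1 to compound 4 (1.59 log units; beyond the scatter). Compound 4 is therefore estimated at 1 ug/mL, with a range from 0.15 ug/mL to 6 ug/mL.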

Compound 4, half-maximal effective concentration: 1.3 ug/mL
Estimate against measurement, compound 4: 1.3-fold (0.11 log units) below, within the range that was stated.
By their numbers in this assay, from the lowest: compound 1; then compound 2; then compound 4; then compound 3.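

Oxolan-2-yl brings the first non-aromatic ring to this carbonyl carbon, and in this assay the rise seen with the two substituted phenyl groups recurs: a 50-fold higher number from compound 1 to compound 4 (1.70 log units; beyond the scatter). The large rise is therefore not confined to exchanges that keep an aromatic ring here, and compound 1 remains the lowest of the four. The replacement groups also lie much closer to one another than to 1-methyl-4-nitro-1H-pyrazol-5-yl, with a 2.0-fold higher number from compound 2 to compound 4 (0.31 log units; beyond the scatter) and a 2.5-fold lower number from compound 3 to compound 4 (0.40 log units; beyond the scatter), both modest beside the step away from compound 1, and no measurement at hand explains that separation.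

These compounds do not separate the contribution of the nitro group from that of the pyrazole ring, since every replacement removes both at once. Going by these compounds, a 1-methyl-1H-pyrazol-5-yl group without the nitro, or a nitro group carried on a phenyl ring, would address that question, while an open chain, an amine or a carboxylic acid at this carbonyl carbon remains unexplored ground.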